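The source may hold more compounds than are shown below. What is called first, only, known or untested is meant among the compounds shown, and "the series" means these compounds.

Measured compounds:
Compound 1, `CNC(=O)NCCS(=O)(=O)NC(=O)c1ccc(Nc2nc(NC3(c4ccc(Cl)cc4)CC3)nc(OCC(F)(F)F)n2)cc1`: 40 nm/s
Compound 2, `CC(=O)NCCS(=O)(=O)NC(=O)c1ccc(Nc2nc(NC3(c4ccc(Cl)cc4)CC3)nc(OCC(F)(F)F)n2)cc1`: 7 nm/s
Compound 3, `COC(=O)NCCS(=O)(=O)NC(=O)c1ccc(Nc2nc(NC3(c4ccc(Cl)cc4)CC3)nc(OCC(F)(F)F)n2)cc1`: 39 nm/s

The three compounds share one core and differ only at the end of the side chain, on a carbonyl carbon. In a physicochemical assay for permeability, using PAMPA, at pH 7.4 (a higher number here means that the compound crosses the layer faster, a lower number that the compound crosses the layer more slowly), compound 3 gives 39 nm/s, the second highest of the three numbers. For the measured compounds named here, one step here is a 1.0-fold lower number from compound 1 to compound 3 (0.01 log units; within the scatter), while a 5.6-fold higher number from compound 2 to compound 3 (0.75 log units; beyond the scatter) is the one step here that stands beyond the scatter. Compound 4, `O=C(NS(=O)(=O)CCNCc1ccccc1)c1ccc(Nc2nc(NC3(c4ccc(Cl)cc4)CC3)nc(OCC(F)(F)F)n2)cc1`, is not yet measured in this assay. It differs from compound 3 by benzyl in place of methoxycarbonyl on an amine nitrogen. Going by the values given here, none of the measured steps covers this change: a 5.7-fold lower number from compound 1 to compound 2 (0.76 log units; beyond the scatter) and a 5.6-fold higher number from compound 2 to compound 3 (0.75 log units; beyond the scatter) concern substituents on the carbonyl carbon, whereas in compound 4 the carbonyl carbon itself leaves. Among the compounds with values here, the measured steps show only that changes at this end of the chain have moved the number by modest amounts, so the expectation for compound 4 must be drawn broadly. Compound 4 is estimated at 20 nm/s, with a range from 5 nm/s to 80 nm/s, which means an expected step of a 2.0-fold lower number from compound 3 to compound 4 (0.29 log units; within the scatter).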

Compound 4, apparent permeability: 49 nm/s
Estimate against measurement, compound 4: 2.5-fold (0.39 log units) below, within the range that was stated.
By their numbers in this assay, from the lowest: compound 2; then compounds 3, 1 and 4 (each within the scatter of the next).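

With benzyl on the amine nitrogen, the carbonyl is gone and a six-membered aromatic ring of carbon only has entered, yet in this assay the comparison with methoxycarbonyl gives a 1.3-fold higher number from compound 3 to compound 4 (0.10 log units; within the scatter) and the comparison with methylcarbamoyl gives a 1.2-fold higher number from compound 1 to compound 4 (0.09 log units; within the scatter) as the reading. For the compounds shown here, the earlier compounds varied only the substituent on the carbonyl carbon, so this is the first sign that a carbonyl at this place is not required for a number at the level of compound 1 and compound 3; compound 2 stays apart from the rest, with acetyl replaced by benzyl giving a 7.0-fold higher number from compound 2 to compound 4 (0.85 log units; beyond the scatter) as its step. Nothing measured here accounts for these numbers or for the separate position of compound 2.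

Open, from the compounds shown here alone, is how a free amine, with neither acyl nor benzyl on this nitrogen, or a carboxylic acid at the end of the chain would read in this assay. Also open, going by these compounds, is whether propanoyl would fall with acetyl in compound 2 or with the other three groups, and whether a longer chain between the phenyl ring and the amine nitrogen would keep the number of compound 4.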